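A few compounds are considered here, and "the series" means these few. Any claim that something is new, unique, unknown or untested is made for them only; others in the source may bear on it.

Measured so far in a functional assay on the whole organism with Rattus norvegicus as the target, at a dose of 20 mg/kg by the intraperitoneal route; a lower number here means less inhibition, a higher number more inhibition at the dose given (going by the name of the read-out):
compound 1 `Nc1nc(N)nc(-c2ccccc2[N+](=O)[O-])n1` gives 11%
compound 2 `Nc1nc(N)nc(-c2ccc([N+](=O)[O-])cc2)n1` gives 41%
compound 3 `Cc1ccccc1-c1nc(N)nc(N)n1` gives 28%

Compound 2 stands highest of the three, beyond the scatter from both others. Compound 1 and compound 2 are built from the same atoms joined differently; the difference between the two cores is not broken down here. From compound 1 to compound 3 the change is methyl in place of nitro on an aromatic carbon and the step is a number 17 percentage points higher from compound 1 to compound 3 (beyond the scatter).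

Compound 4 `Cc1ccc(-c2nc(N)nc(N)n2)cc1` is not yet measured. From compound 2 it differs by methyl in place of nitro on an aromatic carbon. This is the same kind of change as that from compound 1 to compound 3, not the same: there the methyl sits ortho to a group of 8 heavy atoms, here para to it.

Beside a number 17 percentage points higher from compound 1 to compound 3 (beyond the scatter), the step expected for compound 4 is a number 11 percentage points higher from compound 2 to compound 4 (beyond the scatter), resting only on that single precedent, with the change of place adding uncertainty. Compound 4 is accordingly estimated at 52%, between 32% and 72%.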

Compound 4, a percentage reported as inhibition, in the whole organism at one dose (the size of the read-out at that dose, not a potency) in the Rattus norvegicus assay: 54%
Compound 4: middle estimate off by 2 percentage points, on the low side, and the stated range covers the measured number.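

In the Rattus norvegicus assay, methyl in place of nitro gives a number 13 percentage points higher from compound 2 to compound 4 (beyond the scatter), and the step carries over from one core to the other with no difference beyond the scatter: the same change on two cores in the Rattus norvegicus assay, a number 17 percentage points higher (beyond the scatter) from compound 1 to compound 3 and a number 13 percentage points higher (beyond the scatter) from compound 2 to compound 4, 4 percentage points apart, within the scatter of two such steps

In a physicochemical assay for lipophilicity (on this read-out lower numbers stand for lower lipophilicity and higher numbers for higher lipophilicity), compound 2 gives 1.6 and compound 4 gives 1.92, so the change also shifts this read-out on this core. These two cores do not show that the step would hold on a third core, nor which feature of the change produces it.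

The compounds shown leave open whether an amine, a carboxylic acid or a longer chain in place of nitro would give a step of similar size. They also leave open whether a larger step in one read-out goes with a larger step in the other.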